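Trimming one carbon from the side chain of compound 2

The source may report more compounds than this note shows. Statements on the series, on what has been measured and on what is new or still open speak of the compounds shown alone.

Compound 1 `CC(C)(C)C1=CC(=O)C=C(NCCC(=O)O)C1=O` gives 28400 nM
Compound 2 `CC1=CCC[C@H]2[C@](C)(CC3=CC(=O)C=C(N[C@@H](CC(C)C)C(=O)O)C3=O)[C@@H](C)CC[C@]12C` gives 10900 nM
Compound 3 `CC(C)[C@@H](NC1=CC(=O)C=C(C(C)(C)C)C1=O)C(=O)O` gives 24600 nM

In a functional assay on Fem-X cells (Homo sapiens) for cytotoxicity, read by MTT assay, with a stated time of 72 h (on this read-out higher numbers stand for weaker inhibition and lower numbers for stronger inhibition), compound 2 (10900 nM) has the lowest number of the three, and the other two lie beyond the scatter from it. Compound 4 `CC1=CCC[C@H]2[C@](C)(CC3=CC(=O)C=C(N[C@@H](C(=O)O)C(C)C)C3=O)[C@@H](C)CC[C@]12C` is still unmeasured. It differs from compound 2 in one place (1-carboxy-2-methylpropyl in place of 1-carboxy-3-methylbutyl on an amine nitrogen), with 1-carboxy-2-methylpropyl in place of 1-carboxy-3-methylbutyl on an amine nitrogen. For the measured compounds named here, no measured pair isolates this change. Compound 3 (24600 nM) carries the same group on a different core, so it offers only a loose hint. In this assay a slight rise is expected, with no step beyond the scatter. The estimated move is a 1.2-fold higher number from compound 2 to compound 4 (0.08 log units; within the scatter) and should stay small. For compound 4 the estimated value is 13000 nM (expected range 6500 nM to 26000 nM).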

Compound 4, half-maximal inhibitory concentration: 11400 nM
The estimate for compound 4 lay 1.1-fold (0.06 log units) above the measured number; the range from low to high includes it.
By their numbers in this assay, from the lowest: compounds 2 and 4 (each within the scatter of the next); then compounds 3 and 1 (each within the scatter of the next).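

For the compounds shown here, this pair is the first to isolate a change at this position, on an amine nitrogen of the shared core. In this assay the move from 1-carboxy-3-methylbutyl to 1-carboxy-2-methylpropyl gives a 1.0-fold higher number from compound 2 to compound 4 (0.02 log units; within the scatter) and stays within the scatter, so the two side chains cannot be told apart here. The compounds shown leave open whether a longer chain, or a side chain carrying an amine instead of the carboxylic acid, would shift the number on this core. Nothing measured gives a reason why these two groups read alike.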